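The source may report more compounds than this note shows. Statements on the series, on what has been measured and on what is new or still open speak of the compounds shown alone.

Compound 3 `C=CC(=O)Nc1cccc(NC(=O)CSc2nc(Nc3ccc(Br)cc3)c3ccccc3n2)c1` is the second highest of three numbers in a functional assay on PC-3 cells (Homo sapiens) for inhibition, read by MTT assay, with a stated time of 72 h (on this read-out higher numbers stand for weaker inhibition and lower numbers for stronger inhibition), where compound 3 gives 12400 nM. Compound 1 `C=CC(=O)Nc1cccc(NC(=O)CSc2nc(Nc3cccc(Cl)c3)c3ccccc3n2)c1` gives 12300 nM in this assay, and the pair sit within the scatter of each other: a 1.0-fold higher number from compound 1 to compound 3 (0.00 log units; within the scatter). Compound 2 `C=CC(=O)Nc1cccc(NC(=O)CSc2nc(Nc3cccc(OC)c3)c3ccccc3n2)c1` gives 34900 nM, and the step of a 2.8-fold lower number from compound 2 to compound 3 (0.45 log units; beyond the scatter) is modest but beyond the scatter. The next change, (2,4-dichlorophenyl in place of 4-bromophenyl on a nitrogen on an aromatic ring), gives compound 4 `C=CC(=O)Nc1cccc(NC(=O)CSc2nc(Nc3ccc(Cl)cc3Cl)c3ccccc3n2)c1`. Of the measured steps, only the halogen-to-halogen move a 1.0-fold higher number from compound 1 to compound 3 (0.00 log units; within the scatter) bears directly, and it produced no change; the methoxy comparison is less relevant. The step of a 1.1-fold lower number from compound 3 to compound 4 (0.05 log units; within the scatter) is therefore expected to lie within the scatter. Compound 4 is estimated at 11000 nM, with a range from 5000 nM to 25000 nM.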

Compound 4, half-maximal inhibitory concentration: 25700 nM
The estimate for compound 4 lay 2.3-fold (0.37 log units) below the measured number; the measured number lies above the stated range.
By their numbers in this assay, from the lowest: compounds 1 and 3 (each within the scatter of the next); then compounds 4 and 2 (each within the scatter of the next).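

On the aryl group at this nitrogen, halogen exchange is no longer neutral in this assay: the 2,4-dichlorophenyl group gives a 2.1-fold higher number from compound 3 to compound 4 (0.32 log units; beyond the scatter) and a 2.1-fold higher number from compound 1 to compound 4 (0.32 log units; beyond the scatter). Compound 4 therefore separates from the other halogenated compounds, showing that a halogenated aryl group here does not guarantee a number like theirs. Against the 3-methoxyphenyl group, the change gives only a 1.4-fold lower number from compound 2 to compound 4 (0.13 log units; within the scatter).

On these data alone, whether an aminophenyl or carboxyphenyl group on this nitrogen would fall with either pair remains open. The data give no basis for explaining the difference at this position.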